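Trifluoromethyl gem-diol amides: aryl cap variation against HDAC6

The source may report more compounds than this note shows. Statements on the series, on what has been measured and on what is new or still open speak of the compounds shown alone.

Measured so far:
compound 1 `O=C(CCCCCCNC(=O)C(O)(O)C(F)(F)F)Nc1ncc(-c2ccc(Br)cc2)s1`: 35000 nM
compound 2 `COc1ccc(NC(=O)CCCCCCNC(=O)C(O)(O)C(F)(F)F)cc1`: 440000 nM

In an assay on isolated protein for inhibition of protein deacetylase HDAC6 (Homo sapiens), read by chemiluminescence, with a stated time of 3 h (on this read-out higher numbers stand for weaker inhibition and lower numbers for stronger inhibition), compound 2 gives 440000 nM, the highest of the two numbers recorded; the nearest is compound 1, whose value in this assay is 35000 nM, and the gap between them lies beyond the scatter. Going by the values given here, no single-point step between measured compounds exists in this set.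

Compound 3 `O=C(CCCCCCNC(=O)C(O)(O)C(F)(F)F)Nc1ccc(Br)cc1` remains to be measured. It differs from compound 2 by bromo in place of methoxy on an aromatic carbon. Nothing measured here isolates this exchange, so the size of its effect is open. Compound 1 also carries a bromophenyl cap, though with a different core, and its lower value gives a weak hint. A modest downward step is expected, a 2.2-fold lower number from compound 2 to compound 3 (0.34 log units; beyond the scatter), within or near the scatter. Compound 3 is expected to give 200000 nM, with a range from 60000 nM to 600000 nM.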

Compound 3, half-maximal inhibitory concentration: 100000 nM
Compound 3: the middle estimate sits 2.0-fold (0.30 log units) above what was measured, and the stated range covers the measured number.
By their numbers in this assay, from the lowest: compound 1; then compound 3; then compound 2.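

In this assay, going by these compounds alone, bromo in place of methoxy on an aromatic carbon para to a large group gives a 4.4-fold lower number from compound 2 to compound 3 (0.64 log units; beyond the scatter) and so provides the first single-change reading. This shows that the group at this position alone can shift the number beyond the scatter, although the step is modest and compound 3 still stands at 100000 nM in this series. No measurement here bears on what lies behind the shift.

Going by these compounds, with only methoxy and bromo compared here, it remains open how an amine, a carboxylic acid or a nitrile would read at this position. Also open, on these data alone, are whether a longer chain would shift the number and whether the same exchange would give a similar step on the core of compound 1.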